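A few compounds are considered here, and "the series" means these few. Any claim that something is new, unique, unknown or untested is made for them only; others in the source may bear on it.

Three compounds have so far been tested in an ADME assay on Huh-7 cells (Homo sapiens) for cytotoxicity; on this read-out lower numbers stand for higher toxicity in this test and higher numbers for lower toxicity in this test:

compound 1 `NC(=S)n1ccc2c(OCCCCCOc3ccc(Cl)cc3)cccc21` — 24700 nM
compound 2 `O=C(NC(=S)N1CCc2cc(OCc3ccccc3)ccc21)c1ccccc1` — 45200 nM
compound 3 `N#Cc1cccc(C(=O)NC(=S)N2CCc3c(OCCCCCOc4ccc(Cl)cc4)cccc32)c1` — 9750 nM

Compound 3 gives the lowest number of the three; its gaps to compound 1 and to compound 2 both lie beyond the scatter, so within this small set compound 3 is the most cytotoxic in this assay.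

Compound 4 `CC(C)(C)c1ccc(C(=O)NC(=S)N2CCc3c(OCCCCCOc4ccc(Cl)cc4)cccc32)cc1` has not yet been measured. It differs from compound 3 in one place: 4-(tert-butyl)phenyl in place of 3-cyanophenyl on a carbonyl carbon. For the measured compounds named here, no measured pair shows this change, so nothing in the data fixes its size or direction in this assay. The step from compound 3 to compound 4 is expected to be modest, toward a somewhat lower number, about a 1.3-fold lower number from compound 3 to compound 4 (0.11 log units; within the scatter). Compound 4 is therefore estimated at 7500 nM in this assay, with a range from 2500 nM to 22000 nM.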

Compound 4, half-maximal cytotoxic concentration: > 50000 nM
Compound 4 ended at the assay's limit; the forecaster's own chance of this, stated with the estimate: 5%; middle value at least 6.6-fold (0.82 log units) from the limit.
By their numbers in this assay, from the lowest: compound 3; then compounds 1 and 2 (each within the scatter of the next). At a limit, above all of these: compound 4.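

On the carbonyl carbon, the group carried by the amide-type nitrogen's acyl partner clearly matters in this assay: 4-(tert-butyl)phenyl in place of 3-cyanophenyl gives an at least 5.1-fold higher number from compound 3 to compound 4 (0.70 log units; beyond the scatter), the first single-place change readable in this series. Compound 4 gives > 50000 nM, which is a limit of the assay and not a number, so the step has a lower bound but no known size: the limit of > 50000 nM in this assay, at which 1 of the 4 values shown sits. From the compounds shown here alone, whether the loss of the nitrile or the arrival of the tert-butyl group carries the step stays open. Going by these compounds, the reading with a carboxylic acid or an amine on that phenyl ring is also open.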